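The compounds below may be only part of what the source reports. "The series", "measured", "known", "first", "only" and "open" are said of these compounds alone.

Working notes on the series. Compound 1 `C=C1CC[C@@H]2[C@](C)(CO)[C@H](O)CC[C@@]2(C)[C@@H]1CC=O` carries the shared core with a short aldehyde-terminated side chain. In a functional assay on BMMC cells (Mus musculus, strain C57BL/6) for inhibition, with stated times of 5 days and 48 h (on this read-out higher numbers stand for weaker inhibition and lower numbers for stronger inhibition), compound 1 gives > 30000 nM, which is a limit of the assay and not a number. Compound 2 `C=C1CC[C@@H]2[C@](C)(CO)[C@H](O)CC[C@@]2(C)[C@@H]1C/C=C(/C(=O)O)[C@H](O)CO` extends that side chain into an unsaturated acid bearing a diol. In this assay compound 2 gives > 30000 nM, again a limit rather than a measured number. Compound 3 `C=C1CC[C@@H]2[C@](C)(CNCc3ccccc3)[C@H](O)CC[C@@]2(C)[C@@H]1/C=C/C1=CCOC1=O` replaces the primary alcohol on the core with a benzylamino group and carries an unsaturated lactone on the side chain. In this assay compound 3 gives 960 nM. Going by the values given here, this is the only number in the set: the other two values sit at the limit of > 30000 nM in this assay, at which 2 of the 3 values shown sit, so compound 3 is the single measurable point of the three, and no pair of measured compounds differing in one place exists from which a step size could be read.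

Compound 4 `C=C1CC[C@@H]2[C@](C)(CNCc3cccc(OC)c3)[C@H](O)CC[C@@]2(C)[C@@H]1/C=C/C1=CCOC1=O` differs from compound 3 by methoxy in place of hydrogen on an aromatic carbon. Among the compounds with values here, with no measured step of comparable kind available, the step from compound 3 to compound 4 is expected to be small, a 1.1-fold lower number from compound 3 to compound 4 (0.05 log units; within the scatter), and not beyond the usual scatter in either direction. Compound 4 is therefore estimated at 850 nM, with a range from 300 nM to 2500 nM.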

Compound 4, half-maximal inhibitory concentration: 780 nM
Beside the measured number, compound 4's estimate is 1.1-fold (0.04 log units) above it; the measured number falls inside the stated range.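

Methoxy in place of hydrogen on an aromatic carbon, meta to a large group, gives the only readable step of the series in this assay: a 1.2-fold lower number from compound 3 to compound 4 (0.09 log units; within the scatter). Going by these compounds alone, the aromatic ring of the benzylamino group therefore accepts this change, benzylamino to (3-methoxybenzyl)amino, with a shift that stays within the scatter, which the earlier compounds, with a single number among them, could not show. Steps involving compound 1 or compound 2 cannot be read, and these two compounds add nothing on this position: the limit of > 30000 nM in this assay, at which 2 of the 4 values shown sit.

The compounds shown leave open whether a different group on this aromatic carbon, such as an amine, a carboxylic acid, trifluoromethyl or a longer alkoxy chain, would also leave the number within the scatter, and whether methoxy elsewhere on the ring would do the same. Within the data shown here, no single-place pair among them separates the contribution of the benzylamino group from that of the unsaturated lactone on the side chain of the shared core.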